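One More Carbon Toward the Phenyl Ring

The source may hold more compounds than are shown below. What is called first, only, known or untested is meant among the compounds shown, and "the series" means these compounds.

Two compounds have been measured so far in an assay on membranes from Sf9 cells for displacement of a labelled ligand from histamine H2 receptor (Homo sapiens), read by scintillation counting, with a stated time of 60 min; on this read-out higher numbers stand for weaker inhibition and lower numbers for stronger inhibition:

compound 1 `Cc1nc(N)sc1CCCN/C(N)=N/C(=O)NCC(C)CCc1ccccc1` gives 63.1 nM
compound 2 `N/C(=N\C(=O)NC1CCCCC1)Nc1cccc(-c2csc(N)n2)c1` gives 4470 nM

Compound 1 has the lower of the two numbers, so it is the stronger binder of the pair. Compound 2 sits far higher, and the gap between the two values lies well beyond the usual scatter of repeated measurements. The two compounds differ in many places at once, so nothing can be read from that gap about any single change.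

The next compound to be measured is compound 3 `Cc1nc(N)sc1CCCN/C(N)=N/C(=O)NCC(C)CCCc1ccccc1`. It differs from compound 1 in one spot only: benzyl in place of phenyl on a saturated chain carbon, four bonds along the chain from an amide-type nitrogen. In other words, the flexible chain that ends in the aromatic ring grows by one carbon. Going by the values given here, no pair of measured compounds shows what such a single-carbon extension does here, so there is no measured step to lean on. Because compound 1 already gives 63.1 nM, the expectation is that compound 3 stays close to it, with a step of a 1.1-fold lower number from compound 1 to compound 3 (0.02 log units; within the scatter) that would not pass beyond the scatter in either direction. Compound 3 is therefore estimated at 60 nM, within a range from 20 nM to 200 nM.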

Compound 3, inhibition constant: 60.3 nM
For compound 3 the middle estimate is 1.0-fold (0.00 log units) below the measured one; low and high end bracket the measured number.
By their numbers in this assay, from the lowest: compounds 3 and 1 (each within the scatter of the next); then compound 2.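

In this assay, placing benzyl in place of phenyl on a saturated chain carbon, four bonds along the chain from an amide-type nitrogen, gives a 1.0-fold lower number from compound 1 to compound 3 (0.02 log units; within the scatter). Going by these compounds alone, this is the first single-place comparison: the end of the chain reads as phenethyl in compound 1 and as 3-phenylpropyl in compound 3, and the two compounds cannot be told apart on this read-out, so at this position the chain can take either length without a measurable loss of binding. Why the two numbers match remains unexplained, as no measurement bears on the reason for this result.

On these data alone, two chain lengths within the scatter of each other mark out only a short stretch, so it remains open whether a longer chain such as 4-phenylbutyl, or a shorter one ending in benzyl, would also keep the number in this range. Also open, as far as these compounds go, is whether the phenyl ring at the chain end is needed at all, which a chain ending in an amine or a carboxylic acid would test.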